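The source may report more compounds than this note shows. Statements on the series, on what has been measured and on what is new or still open speak of the compounds shown alone.

Among the compounds with values here, in a functional assay on A549 cells (Homo sapiens) for antiproliferative activity, read by MTT assay, with a stated time of 72 h (a higher number here means a weaker inhibitor, a lower number a stronger inhibitor), compound 2 `COc1cc(-n2cnc3ccc(-c4cccc(C)c4)cc32)cc(OC)c1OC` gives 3820 nM, the higher of the two numbers so far; compound 1 `COc1ccc(-c2ccc3ncn(-c4cc(OC)c(OC)c(OC)c4)c3c2)cc1F` gives 1430 nM. Within the data shown here, the only step to hand, a 2.7-fold higher number from compound 1 to compound 2 (0.43 log units; beyond the scatter), is modest yet beyond the scatter. Compound 3 `COc1cccc(-c2ccc3ncn(-c4cc(OC)c(OC)c(OC)c4)c3c2)c1` differs from compound 2 by methoxy in place of methyl on an aromatic carbon. This change recovers only part of what separates compound 1 from compound 2, so in this assay a small movement toward compound 1 is expected because of a 2.7-fold higher number from compound 1 to compound 2 (0.43 log units; beyond the scatter), possibly none beyond the scatter. For compound 3 the estimate is 2400 nM, range 900 nM to 6500 nM. The expected step is a 1.6-fold lower number from compound 2 to compound 3 (0.20 log units; within the scatter).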

Compound 3, half-maximal inhibitory concentration: 3180 nM
Compound 3: middle estimate off by 1.3-fold (0.12 log units), on the low side; the range from low to high includes it.
By their numbers in this assay, from the lowest: compound 1; then compounds 3 and 2 (each within the scatter of the next).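

In this assay, methoxy in place of methyl on this aromatic carbon, meta to a large group, gives a 1.2-fold lower number from compound 2 to compound 3 (0.08 log units; within the scatter) and leaves the two groups indistinguishable here. The 3-methoxyphenyl group alone does not close the gap to the 3-fluoro-4-methoxyphenyl group, with a 2.2-fold higher number from compound 1 to compound 3 (0.35 log units; beyond the scatter) still standing. No measurement at hand offers an explanation for either step. Which part of the 3-fluoro-4-methoxyphenyl group carries the gap stays open. So does the effect of an amine or a carboxylic acid at this place.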